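A few compounds are considered here, and "the series" means these few. Any claim that something is new, unique, unknown or untested is made for them only; others in the source may bear on it.

Of the compounds shown here, two that share one core have been tested in a functional assay on LoVo cells (Homo sapiens) for antiproliferative activity, read by sulforhodamine B assay, with a stated time of 48 h; a higher number here means a weaker inhibitor, a lower number a stronger inhibitor. Compound 1 `N=C(N)NS(=O)(=O)c1ccc(N/C(S)=N\c2ccnc3cc(C(F)(F)F)ccc23)cc1` gives 23900 nM in this assay. Among the measured compounds shown here, compound 2 `O=S(=O)(Nc1nccs1)c1ccc(N/C(S)=N\c2ccnc3cc(C(F)(F)F)ccc23)cc1` gives 67100 nM in this assay, the higher of the two numbers, so it is the weaker of this pair; the only step measured so far, a 2.8-fold higher number from compound 1 to compound 2 (0.45 log units; beyond the scatter), came from exchanging one group on the sulfonamide nitrogen. Compound 3 `O=S(=O)(Nc1ccccn1)c1ccc(N/C(S)=N\c2ccnc3cc(C(F)(F)F)ccc23)cc1` differs from compound 2 by the change (pyridin-2-yl in place of 1,3-thiazol-2-yl on a sulfonamide nitrogen). For the measured compounds named here, the one measured step bears only loosely on this, since that step exchanged an open chain for a ring, whereas here one aromatic ring replaces another on the same nitrogen. The step of a 1.3-fold lower number from compound 2 to compound 3 (0.13 log units; within the scatter) is therefore expected to be small, most likely inside the scatter, with no clear direction. Compound 3 is estimated at 50000 nM in this assay, within a range from 18000 nM to 140000 nM.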

Compound 3, half-maximal inhibitory concentration: 87500 nM
The estimate for compound 3 lay 1.8-fold (0.24 log units) below the measured number; the range from low to high includes it.
By their numbers in this assay, from the lowest: compound 1; then compounds 2 and 3 (each within the scatter of the next).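

In this assay, exchanging one aromatic ring for another on the sulfonamide nitrogen has no effect that can be told from the usual scatter: pyridin-2-yl in place of 1,3-thiazol-2-yl gives a 1.3-fold higher number from compound 2 to compound 3 (0.12 log units; within the scatter). At this position, therefore, the six-membered aromatic ring and the five-membered one cannot be separated by this measurement. The open-chain group of compound 1 now has a second ring to be compared with, and the step of a 3.7-fold higher number from compound 1 to compound 3 (0.56 log units; beyond the scatter) shows that both ring-bearing compounds give clearly higher numbers than compound 1.

No measured evidence accounts for these differences. On these data alone, it remains open how a plain phenyl ring, a small methyl group or a simple hydrogen on this nitrogen would compare.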